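The source may report more compounds than this note shows. Statements on the series, on what has been measured and on what is new or still open speak of the compounds shown alone.

Compound 1 `O=c1cc(CSc2nc3ccccc3s2)oc2ccccc12` and compound 2 `O=c1cc(CSc2nc3ccccc3s2)oc2ccc(Cl)cc12` share one core, while compound 3 `Nc1nnc(SCc2cc(=O)c3ccccc3o2)s1` is built on another; the difference between the two cores is not broken down here. In a functional assay on MDA-MB-435S cells (Homo sapiens) for cytotoxicity, read by MTT assay, with a stated time of 72 h (a higher number here means a weaker inhibitor, a lower number a stronger inhibitor), compound 1 gives only a limit of the assay, > 25000 nM. Compound 2 likewise gives only a limit in this assay, > 25000 nM. Compound 3 also gives only a limit in this assay, > 25000 nM. The change from compound 1 to compound 2 is chloro in place of hydrogen on an aromatic carbon, and the resulting step that the two limits leave unreadable from compound 1 to compound 2 cannot be read, because the limit of > 25000 nM in this assay, at which 3 of the 3 values shown sit, leaves no room for a number. Compound 4 `Nc1nnc(SCc2cc(=O)c3cc(Cl)ccc3o2)s1` has not yet been measured; it differs from compound 3 by the same change, (chloro in place of hydrogen on an aromatic carbon), at the same place. The step from compound 3 to compound 4 in this assay is expected to be a step that the limit leaves unreadable from compound 3 to compound 4, an expectation that rests on compound 1 and compound 2, which both sit at the limit, as the limit of > 25000 nM in this assay, at which 3 of the 3 values shown sit, shows. Compound 4 is therefore expected to give 35000 nM, within a range from 12000 nM to 120000 nM.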

Compound 4, half-maximal inhibitory concentration: > 25000 nM
Compound 4 gave a limit, no number; the forecaster's own chance of this, stated with the estimate: 85%; the middle value is on the limit's open side.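

No new step can be read: the change from compound 3 to compound 4 stays unreadable, like the one from compound 1 to compound 2, because all of these compounds give only a limit: the limit of > 25000 nM in this assay, at which 4 of the 4 values shown sit.

The compounds shown leave open how strong each one really is in this assay, and whether chloro in place of hydrogen on an aromatic carbon alters that strength on either core.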